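A few compounds are considered here, and "the series" means these few. Any claim that something is new, unique, unknown or untested is made for them only; others in the source may bear on it.

Of the compounds shown here, two built on one shared core have been measured in a functional assay for inhibition, with Homo sapiens as the target; a lower number here means a stronger inhibitor, a higher number a weaker inhibitor. Compound 1 `CCCCCS(=O)(=O)N[C@@H](CNC(=O)c1ccc2c(c1)C(=O)N(CCC1CCNCC1)C2)C(=O)O` gives 9 nM, and compound 2 `CCCCNC(=O)N[C@@H](CNC(=O)c1ccc2c(c1)C(=O)N(CCC1CCNCC1)C2)C(=O)O` gives 16 nM. Among the compounds with values here, compound 2 therefore stands within the scatter of compound 1, the only other measured compound, so the numbers set neither apart. Compound 3 `CCCCNS(=O)(=O)N[C@@H](CNC(=O)c1ccc2c(c1)C(=O)N(CCC1CCNCC1)C2)C(=O)O` keeps the core of compound 2 and alters one group: butylsulfamoyl in place of butylcarbamoyl on an amine nitrogen. In words, butylsulfamoyl stands in place of butylcarbamoyl on an amine nitrogen. Within the data shown here, only one measured step bears on this change, a 1.8-fold higher number from compound 1 to compound 2 (0.25 log units; within the scatter), in which butylcarbamoyl took the place of pentylsulfonyl on an amine nitrogen. That single step stayed within the scatter, and it is thin evidence, but it gives no reason to expect a large move in this assay from a further exchange of this group. The expected change is a 1.3-fold lower number from compound 2 to compound 3 (0.12 log units; within the scatter), which would be no step beyond the scatter. Compound 3 is estimated at 12 nM, with an expected range from 5 nM to 30 nM.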

Compound 3, half-maximal inhibitory concentration: 19 nM
Compound 3: the middle estimate sits 1.6-fold (0.20 log units) below what was measured, and the stated range covers the measured number.
By their numbers in this assay, from the lowest: compounds 1, 2 and 3 (each within the scatter of the next, the first and the last beyond it).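

In this assay, butylsulfamoyl in place of butylcarbamoyl on an amine nitrogen gives a 1.2-fold higher number from compound 2 to compound 3 (0.07 log units; within the scatter), so this position has now taken a urea-type and a sulfamoyl-type group with no step beyond the scatter between them. Butylamino in place of pentyl on a sulfonyl sulfur gives a 2.1-fold higher number from compound 1 to compound 3 (0.32 log units; beyond the scatter), the first step in this set to lie beyond the scatter, though only modestly, and it shows that a change at the atom attached to the sulfonyl sulfur can register in this assay even though each of the two neighbouring steps through compound 2 stays within the scatter. No accompanying data bear on the reason for these small differences.

From the compounds shown here alone, all three compounds carry a butyl or pentyl chain at this position, so the effect of a methyl group, a longer chain, a phenyl ring or a chain ending in an amine remains open. The compounds also leave open whether the same small steps would hold with the carboxylic acid or the piperidine of the shared core replaced.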